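The compounds below may be only part of what the source reports. "The series", "measured", "known", "first", "only" and "open" are said of these compounds alone.

Within the data shown here, compound 1 `CN(C)/C=N/c1c(C=O)c(-c2ccccc2)nn1-c1ccccc1` gives 9300 nM in a functional assay on NPC-TW01 cells (Homo sapiens) for inhibition, read by MTT assay, with a stated time of 72 h (a higher number here means a weaker inhibitor of growth, a lower number a stronger inhibitor of growth), and stands highest of the two numbers measured so far, though its nearest neighbour, compound 2 `Cc1cccc(-n2nc(-c3ccccc3)c(C=O)c2/N=C/N(C)C)c1` with 8900 nM, sits within the scatter of it. Among the measured compounds shown here, the single measured step, a 1.0-fold lower number from compound 1 to compound 2 (0.02 log units; within the scatter), methyl in place of hydrogen on an aromatic carbon, therefore shows no change beyond the scatter. Compound 3 `CN(C)/C=N/c1c(C=O)c(-c2ccc(Cl)cc2)nn1-c1ccccc1` is the next unmeasured member; it differs from compound 1 by chloro in place of hydrogen on an aromatic carbon. For the measured compounds named here, no measured step places a group on this part of the molecule, and the one step in hand, from compound 1 to compound 2, alters another part and was itself within the scatter, so it bears on the question only loosely. With nothing in the data pointing to a move beyond the scatter, the step from compound 1 to compound 3 is expected to be a 1.0-fold lower number from compound 1 to compound 3 (0.01 log units; within the scatter). Compound 3 is accordingly estimated at 9000 nM, with a range from 4000 nM to 20000 nM in this assay.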

Compound 3, concentration for 50% growth inhibition: 8100 nM
Compound 3: the middle estimate sits 1.1-fold (0.05 log units) above what was measured; the measured number falls inside the stated range.
By their numbers in this assay, from the lowest: compounds 3, 2 and 1 (each within the scatter of the next).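

In this assay, among these compounds, the change from phenyl to 4-chlorophenyl reads as a 1.1-fold lower number from compound 1 to compound 3 (0.06 log units; within the scatter), the first measured step at this ring, since the earlier methyl step lay elsewhere on the molecule. Chloro para to a large group therefore leaves the number within the scatter, so this one chlorine atom gives no sign that the position affects growth inhibition in this series. Nothing available bears on this result from outside the growth numbers.

On these data alone, whether an amine, a carboxylic acid or a longer chain in place of chloro at this position would move the number beyond the scatter remains open. Also open, as far as these compounds go, is whether replacing the carbonyl group of the shared core with an amide would change the number.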